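This account rests on a few compounds, and the source may have more. Where it says the series, first, only, none or still open, it means among the compounds named here.

Working notes on the series. Compound 1 `CC(C(=O)NCc1ccc(C(F)(F)F)cc1OCc1ccc(F)cc1)c1ccc(NS(C)(=O)=O)c(F)c1` is the compound with the highest number of the two measured; in an assay on CHO cells for antagonist activity at transient receptor potential cation channel subfamily V member 1 (Homo sapiens), read by FLIPR (on this read-out lower numbers stand for stronger inhibition and higher numbers for weaker inhibition), compound 1 gives 0.5 nM. Its nearest neighbour, compound 2 `C[C@H](C(=O)NCc1ccc(C(F)(F)F)cc1SC1CCCCC1)c1ccc(NS(C)(=O)=O)c(F)c1`, gives 0.3 nM in this assay, a gap that sits within the scatter, so the two are not ordered. Compound 3 `CC(C(=O)NCc1ccc(C(F)(F)F)cc1-c1cccnc1)c1ccc(NS(C)(=O)=O)c(F)c1` is not yet measured. It differs from compound 1 by pyridin-3-yl in place of (4-fluorobenzyl)oxy on an aromatic carbon. Among the measured compounds shown here, no step between measured compounds is on hand to calibrate this change, so the expectation rests on the two values shown. A step of a 6.0-fold higher number from compound 1 to compound 3 (0.78 log units; beyond the scatter) toward a higher number is expected, beyond the scatter. Compound 3 is estimated at 3 nM in this assay, in a range of 0.7 nM to 15 nM.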

Compound 3, inhibition constant: 59.4 nM
Compound 3: middle estimate off by 20-fold (1.30 log units), on the low side, outside the stated range (above it).
By their numbers in this assay, from the lowest: compounds 2 and 1 (each within the scatter of the next); then compound 3.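

In this assay, among the compounds shown here, this position, ortho to a large group and meta to a trifluoromethyl group, proves far from indifferent to its substituent: pyridin-3-yl in place of (4-fluorobenzyl)oxy gives a 120-fold higher number from compound 1 to compound 3 (2.07 log units; beyond the scatter) and this is the first large step. Nothing at hand gives a reason for this step. Still open, going by these compounds, is whether plain phenyl or a (pyridin-3-yl)methoxy group at this carbon would stay close to compound 1, which would separate the role of the ring nitrogen from that of the oxygen-linked chain.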